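Methoxycarbonyl in place of methylsulfonyl: working notes

This account rests on a few compounds, and the source may have more. Where it says the series, first, only, none or still open, it means among the compounds named here.

In an ADME assay on CHO cells (Cricetulus griseus) for cytotoxicity, read by MTT assay (on this read-out higher numbers stand for lower toxicity in this test and lower numbers for higher toxicity in this test), compound 1 `CN1CCN(C2CCN(c3nccc4[nH]c(-c5cccc(OC(F)(F)F)c5)nc34)CC2)CC1` gives 3000 nM. Compound 2 `CN1CCN(C2CCN(c3nccc4[nH]c(-c5cccc(S(C)(=O)=O)c5)nc34)CC2)CC1` gives > 50000 nM, which is a limit of the assay and not a number. Compound 3 `COC(=O)c1cccc(-c2nc3c(N4CCC(N5CCN(C)CC5)CC4)nccc3[nH]2)c1` carries methoxycarbonyl in place of methylsulfonyl on an aromatic carbon, (methoxycarbonyl in place of methylsulfonyl on an aromatic carbon). For the measured compounds named here, the only measured step bearing on this change is the large one an at least 16-fold higher number from compound 1 to compound 2 (1.22 log units; beyond the scatter), also made on an aromatic carbon. On that step, a moderate move to a lower number is expected, with the limit still within reach: an at least 3.3-fold lower number from compound 2 to compound 3 (0.52 log units; beyond the scatter). For compound 3 the estimated value is 15000 nM, with an expected range of 5000 nM to 50000 nM.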

Compound 3, half-maximal cytotoxic concentration: 34000 nM
Compound 3: the middle estimate sits 2.3-fold (0.36 log units) below what was measured, and the stated range covers the measured number.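

In this assay, methoxycarbonyl gives a true number on the high side at this aromatic carbon: an 11-fold higher number from compound 1 to compound 3 (1.05 log units; beyond the scatter). The large rise away from trifluoromethoxy therefore no longer rests on a limit alone. The change from methylsulfonyl gives an at least 1.4-fold lower number from compound 2 to compound 3 (0.16 log units; that floor lies within the scatter), so no real drop is established, and for compound 2 the reading of > 50000 nM is a limit and not a number: the limit of > 50000 nM in this assay, at which 1 of the 3 values shown sits.

Still open, from the compounds shown here alone, is the true size of the step between methylsulfonyl and methoxycarbonyl. Also open, going by these compounds, is whether an amine or a carboxylic acid on this carbon would keep the number as high.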